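Fluorine on the phenyl arm of a thiazole acetic acid

The source may hold more compounds than are shown below. What is called first, only, known or untested is meant among the compounds shown, and "the series" means these compounds.

Notes on a small acid series read in an in vitro assay on HEK385-7 cells for displacement of a labelled ligand from prostaglandin D2 receptor 2 (Homo sapiens); a higher number here means a weaker inhibitor, a lower number a stronger inhibitor. For the measured compounds named here, the parent, compound 1 `O=C(O)Cc1sc(C(c2ccccc2)c2ccccc2)nc1-c1ccccc1`, gives 570 nM, the highest number of the three measured members. Compound 3 `O=C(O)Cc1sc(C(c2ccccc2)c2ccc(Cl)cc2)nc1-c1ccc(Cl)cc1` sits nearest to it and gives 45 nM, a gap beyond the usual scatter. Compound 2 `O=C(O)Cc1sc(C(c2ccc(F)cc2)c2ccc(F)cc2)nc1-c1ccnc(F)c1` is furthest away and gives 0.48 nM, far beyond the scatter. Going by the values given here, no pair of measured compounds differs in only one place, so neither gap can be tied to a single change.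

The next compound, compound 4 `O=C(O)Cc1sc(C(c2ccccc2)c2ccccc2)nc1-c1cccc(F)c1`, is compound 1 with one alteration: fluoro in place of hydrogen on an aromatic carbon. Among the compounds with values here, the change is small, one heavy atom on an aromatic carbon, and the measured set carries no direct precedent for it. The two lower numbers of compound 2 and compound 3 both belong to compounds with halogens added on more than one ring, so they suggest at most the direction, not the size.

The expected step of a 1.9-fold lower number from compound 1 to compound 4 (0.28 log units; within the scatter) is a modest gain, of a size that might sit near the edge of the scatter. For compound 4 the estimate in this assay is 300 nM, with a range from 120 nM to 750 nM.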

Compound 4, half-maximal inhibitory concentration: 2.9 nM
The estimate for compound 4 lay 100-fold (2.01 log units) above the measured number; the whole stated range lies above it.
By their numbers in this assay, from the lowest: compound 2; then compound 4; then compound 3; then compound 1.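

In this assay, for the compounds shown here, the replacement of hydrogen by fluoro, phenyl to 3-fluorophenyl, gives a 200-fold lower number from compound 1 to compound 4 (2.29 log units; beyond the scatter), the first step that can be tied to a single change. Going by these compounds alone, no earlier pair differed in only one place, so the halogen-bearing compounds could suggest at most a direction, whereas this result shows that one added fluorine atom on this aromatic carbon is enough to move the number far beyond the scatter, and that this position is highly sensitive to substitution. Nothing shown here accounts for the size of the step.

As far as these compounds go, it remains open whether the gain is specific to fluoro or would also appear with chloro, methyl, methoxy or a nitrile at the same carbon, and whether fluoro on the other carbons of this ring would give a step of similar size. It is also open whether this change would add a similar step to a compound already carrying fluoro or chloro on its other phenyl rings, since no such single-change pair is shown.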